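Changing the Ring at the End of the Chain

The source may report more compounds than this note shows. Statements on the series, on what has been measured and on what is new or still open speak of the compounds shown alone.

Measured so far in a functional assay on A549 cells (Homo sapiens) for antiproliferative activity, read by MTT assay, with a stated time of 48 h; on this read-out higher numbers stand for weaker inhibition and lower numbers for stronger inhibition:
Compound 1 `O=C(/C=C/c1cccc(Br)n1)Nc1ccc2ncnc(Nc3cccc(Cl)c3)c2c1` gives 4160 nM.
Compound 2 `O=C(/C=C/c1ncc2ccccc2n1)Nc1ccc2ncnc(Nc3cccc(Cl)c3)c2c1` gives 3350 nM.

On the numbers alone, compound 2 sits at the lower end of these two, yet the step between them, a 1.2-fold lower number from compound 1 to compound 2 (0.09 log units; within the scatter), is within the scatter, so the two compounds cannot be separated and neither can be called more potent. Compound 3 `O=C(/C=C/c1ccc(Br)s1)Nc1ccc2ncnc(Nc3cccc(Cl)c3)c2c1` has not yet been measured. It differs from compound 2 in one place: 5-bromothiophen-2-yl in place of quinazolin-2-yl on a double-bonded chain carbon bound to a double-bonded chain carbon. Among the compounds with values here, no measured step covers this exact exchange. Within the data shown here, the one step available, a 1.2-fold lower number from compound 1 to compound 2 (0.09 log units; within the scatter), also exchanged the ring on the same chain carbon and stayed within the scatter. On that basis the expected step for compound 3 is a 1.0-fold higher number from compound 2 to compound 3 (0.02 log units; within the scatter), that is, no change beyond the scatter. Compound 3 is therefore estimated at 3500 nM, within a range from 1400 nM to 9000 nM.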

Compound 3, half-maximal inhibitory concentration: 1580 nM
The estimate for compound 3 lay 2.2-fold (0.35 log units) above the measured number; measured number inside the range.
By their numbers in this assay, from the lowest: compound 3; then compounds 2 and 1 (each within the scatter of the next).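

This chain carbon does respond to the ring it carries: in this assay the exchange to 5-bromothiophen-2-yl gives a 2.1-fold lower number from compound 2 to compound 3 (0.33 log units; beyond the scatter) and also a 2.6-fold lower number from compound 1 to compound 3 (0.42 log units; beyond the scatter), both modest in size but beyond the scatter, so compound 3 has the lowest number of the series. Compound 1 and compound 3 both carry a bromine and still differ beyond the scatter, so bromine alone does not set the number here. No independent measurement is available to explain the shift.

Still open, from the compounds shown here alone, is whether the step belongs to the five-membered sulfur ring or to its bromine, which a plain thiophen-2-yl would help to separate. Also open, going by these compounds, is how the number would move with an amine or a carboxylic acid in place of that bromine.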